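Amino for Methyl on a Fused Core in Dogs

This account rests on a few compounds, and the source may have more. Where it says the series, first, only, none or still open, it means among the compounds named here.

Measured compounds:
compound 1, `Cc1ccn2c(C)c(C)nc2c1OCc1ccccc1`: 35%
compound 2, `Cc1nc2c(NCc3ccccc3)cccn2c1N`: 89%

In a functional assay on the whole organism with Canis familiaris (Canis lupus familiaris) as the target, at a dose of 8 mg/kg by the oral route (on this read-out lower numbers stand for a weaker effect and higher numbers for a stronger effect at the one dose given), compound 1 gives 35%, the lower of the two numbers recorded. Compound 2 gives 89% in this assay, and its number stands well above that of compound 1, a gap that lies beyond the usual scatter of the measurement. Among the compounds with values here, no single-point step between measured compounds is available, so the two values say only that one compound is far stronger than the other in this read-out.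

Compound 3, `Cc1ccn2c(N)c(C)nc2c1OCc1ccccc1`, has not yet been measured. It differs from compound 1 as follows: amino in place of methyl on an aromatic carbon. Whether this change will matter in this assay cannot be read from a measured pair; the two structures of compound 1 and compound 3 differ in one place only.

The expectation for compound 3 is a rise beyond the scatter, with a step of a number 20 percentage points higher from compound 1 to compound 3 (beyond the scatter), though a result within the scatter of compound 1 remains possible. Compound 3 is estimated to give 55% in this assay, with a range from 30% to 80%.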

Compound 3, a percentage reported as inhibition, in the whole organism at one dose (the size of the read-out at that dose, not a potency): 64%
Estimate against measurement, compound 3: 9 percentage points below; measured number inside the range.
By their numbers in this assay, from the lowest: compound 1; then compound 3; then compound 2.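

In this assay, amino in place of methyl on an aromatic carbon of the five-membered aromatic ring, next to the ring nitrogen, gives a number 29 percentage points higher from compound 1 to compound 3 (beyond the scatter). Compound 1 and compound 2 differ in more than one place, so their gap could not be tied to any single part of the structure, whereas this pair shows that one change at this position, with the rest of the core of compound 1 held fixed, is enough to move the number beyond the scatter. No measurement offered here accounts for the rise, and the step alone cannot separate the nitrogen atom from the hydrogen-bond donor and acceptor that enter with the amino group.

From the compounds shown here alone, whether a methylamino group, a dimethylamino group or a hydroxyl group on this same carbon would give a number like that of compound 3 stays open. Also open, going by these compounds, is whether amino in place of methyl would bring a similar step with something other than the benzyl ether on the shared core, and, since each number comes from a single dose, how the compounds would compare at other doses.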